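A dimethoxyphenyl swap on a shared core

The source may report more compounds than this note shows. Statements on the series, on what has been measured and on what is new or still open speak of the compounds shown alone.

Values so far in a functional assay on A549 cells (Homo sapiens) for inhibition, read by sulforhodamine B assay, with a stated time of 48 h (on this read-out lower numbers stand for stronger inhibition of growth and higher numbers for weaker inhibition of growth), are these
- compound 1 `COc1ccc(OC)c(C=C(C(=O)/C=C/c2ccc(O)c(OC)c2)C(=O)/C=C/c2ccc(O)c(OC)c2)c1` gives 670 nM
- compound 2 `CCc1ccc(C=C(C(=O)/C=C/c2ccc(OC)c(OC)c2)C(=O)/C=C/c2ccc(OC)c(OC)c2)cc1` gives 630 nM
- compound 3 `COc1ccc(/C=C/C(=O)C(=Cc2cccc(OC)c2OC)C(=O)/C=C/c2ccc(OC)c(OC)c2)cc1OC` gives 670 nM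

Compound 1 at 670 nM is level with compound 3 and within the scatter of compound 2, so the three cannot be told apart. For the measured compounds named here, compound 4 `COc1cc(/C=C/C(=O)C(=Cc2cccc(OC)c2OC)C(=O)/C=C/c2ccc(O)c(OC)c2)ccc1O` has the same atoms as compound 1, joined differently, and the one change is 2,3-dimethoxyphenyl in place of 2,5-dimethoxyphenyl on a double-bonded chain carbon bound to a double-bonded chain carbon with 2,3-dimethoxyphenyl in place of 2,5-dimethoxyphenyl on a double-bonded chain carbon bound to a double-bonded chain carbon. This exact swap has not been measured. The nearest evidence is a 1.1-fold higher number from compound 2 to compound 3 (0.03 log units; within the scatter) for bringing in the same 2,3-dimethoxyphenyl at that place. Expected in this assay on that evidence is no step beyond the scatter. The estimated step is a 1.0-fold lower number from compound 1 to compound 4 (0.01 log units; within the scatter) and stays within the scatter. Compound 4 is estimated at 660 nM with 350 nM to 1250 nM as its expected range.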

Compound 4, concentration for 50% growth inhibition: 420 nM
The estimate for compound 4 lay 1.6-fold (0.20 log units) above the measured number; low and high end bracket the measured number.
By their numbers in this assay, from the lowest: compounds 4, 2, 1 and 3 (each within the scatter of the next).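

For the compounds shown here, compound 4 gives the first step at this place between two groups of the same atoms, and a 1.6-fold lower number from compound 1 to compound 4 (0.20 log units; within the scatter) shows that 2,3-dimethoxyphenyl can stand in for 2,5-dimethoxyphenyl on the core of compound 1 without a change beyond the scatter. This agrees with a 1.1-fold higher number from compound 2 to compound 3 (0.03 log units; within the scatter), which brought in the same group on a different partner. Nothing available bears on why the swap behaves this way. The compounds shown leave open whether a carboxylic acid or an amine on that aromatic ring would move the number beyond the scatter.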